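Swapping the Thiophene Ring of a Tetrahydrofuran Acetogenin Amide

The source may report more compounds than this note shows. Statements on the series, on what has been measured and on what is new or still open speak of the compounds shown alone.

Measured so far:
compound 1, `CCCCCCCCCCCC[C@@H](O)[C@H]1CC[C@H]([C@H](O)CCCCCCCCCCNC(=O)c2cccs2)O1`: 1820 nM
compound 2, `CCCCCCCCCCCC[C@@H](O)[C@H]1CC[C@H]([C@H](O)CCCCCCCCCCNC(=O)c2ccco2)O1`: 15800 nM
compound 3, `CCCCCCCCCCCC[C@@H](O)[C@H]1CC[C@H]([C@H](O)CCCCCCCCCCNC(=O)c2cncs2)O1`: 100000 nM

All three share one core and one long chain ending in an amide; only the aromatic ring on the carbonyl carbon changes. In a functional assay on OVCAR-4 cells (Homo sapiens) for inhibition, read by colorimetric assay and sulforhodamine B assay, with a stated time of 48 h (on this read-out higher numbers stand for weaker inhibition of growth and lower numbers for stronger inhibition of growth), compound 1 gives the lowest number of the three, so it is the strongest grower-inhibitor of this set. The step of an 8.7-fold higher number from compound 1 to compound 2 (0.94 log units; beyond the scatter) is modest, and the step of a 55-fold higher number from compound 1 to compound 3 (1.74 log units; beyond the scatter) is large; between the two weaker compounds the step of a 6.3-fold higher number from compound 2 to compound 3 (0.80 log units; beyond the scatter) is modest.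

Compound 4, `CCCCCCCCCCCC[C@@H](O)[C@H]1CC[C@H]([C@H](O)CCCCCCCCCCNC(=O)c2ccnn2C)O1`, is not yet measured. Its change from compound 1 is 1-methyl-1H-pyrazol-5-yl in place of thiophen-2-yl on a carbonyl carbon. Both earlier steps from compound 1 replace the thiophen-2-yl ring and both weaken inhibition, the ring with two hetero atoms most of all. The entering ring here also has two hetero atoms and two hydrogen-bond acceptors, like the ring of compound 3, so a weakening step beyond the scatter is expected, plausibly between the sizes seen for compound 2 and compound 3. Compound 4 is therefore expected to give 40000 nM in this assay, within a range of 8000 nM to 150000 nM, an expected step of a 22-fold higher number from compound 1 to compound 4 (1.34 log units; beyond the scatter).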

Compound 4, concentration for 50% growth inhibition: 22900 nM
Estimate against measurement, compound 4: 1.7-fold (0.24 log units) above; the range from low to high includes it.
By their numbers in this assay, from the lowest: compound 1; then compounds 2 and 4 (each within the scatter of the next); then compound 3.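

In this assay the 1-methyl-1H-pyrazol-5-yl ring is one more replacement for thiophen-2-yl on the carbonyl carbon that weakens growth inhibition, with a 13-fold higher number from compound 1 to compound 4 (1.10 log units; beyond the scatter) on the step, so thiophen-2-yl keeps the lowest number among the four rings shown. The count of hetero atoms does not settle the outcome on its own: the rings of compound 3 and compound 4 have the same count, yet the swap between them gives a 4.4-fold lower number from compound 3 to compound 4 (0.64 log units; beyond the scatter) and so separates two rings that a simple count would treat alike. Furan-2-yl and 1-methyl-1H-pyrazol-5-yl cannot be ranked against each other here, as the step shows a 1.4-fold higher number from compound 2 to compound 4 (0.16 log units; within the scatter) and stays within the usual scatter.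

No measurement is available that would explain why these rings differ. Also open, from the compounds shown here alone, is whether a plain phenyl ring, a thiophen-3-yl ring or a non-aromatic cyclohexyl group on the same carbonyl carbon would match thiophen-2-yl, and whether the order of the rings would hold with a shorter chain leading to the amide.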